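A few compounds are considered here, and "the series" means these few. Any claim that something is new, unique, unknown or untested is made for them only; others in the source may bear on it.

Measured so far in a physicochemical assay for lipophilicity, in phosphate buffer, measured as octanol-water partition, at pH 11.5; on this read-out higher numbers stand for higher lipophilicity and lower numbers for lower lipophilicity:
compound 1 `CCCCNC(=N)NC(=N)Nc1ccc(Cl)cc1` gives 3.13
compound 2 `CCCCCCCCCCNC(=N)NC(=N)Nc1ccc(Cl)cc1` gives 6.13
compound 3 `CCSc1ccc(NC(=N)NC(=N)NCCCCCCNC(=N)NC(=N)Nc2ccc(SCC)cc2)cc1` gives 5.58

Compound 1 stands lowest of the three numbers in this assay. Its nearest neighbour is compound 3, whose value sits well above it, and the furthest is compound 2, which stands higher still; both gaps lie beyond the scatter.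

Compound 4 `CNC(=N)NC(=N)Nc1ccc(Cl)cc1` is the next compound and differs from compound 1 in one place: hydrogen in place of propyl on a saturated chain carbon bound to an amine nitrogen. For the measured compounds named here, the only measured step that bears on this is the one along the same chain, where compound 2 carries hexyl in place of hydrogen on compound 1's chain: a number 3.00 log units higher from compound 1 to compound 2 (beyond the scatter). That step grows the chain and raises the number. The step to compound 4 shortens the same chain, so a downward step in this assay is expected, smaller than the step to compound 2 because a number 3.00 log units higher from compound 1 to compound 2 (beyond the scatter) covers a longer stretch of chain than the propyl that leaves here.

For compound 4 the expected value is 1.63, with a range from 1.15 to 2.1, a change of a number 1.50 log units lower from compound 1 to compound 4 (beyond the scatter) that is estimated to lie beyond the scatter.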

Compound 4, partition coefficient: 1.58
Estimate against measurement, compound 4: 0.05 log units above; low and high end bracket the measured number.
By their numbers in this assay, from the lowest: compound 4; then compound 1; then compound 3; then compound 2.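

In this assay, this position can now be read in both directions from compound 1: shortening butyl to methyl gives a number 1.55 log units lower from compound 1 to compound 4 (beyond the scatter), set against the rise with the longer chain, a number 3.00 log units higher from compound 1 to compound 2 (beyond the scatter). Across compound 4, compound 1 and compound 2, the number therefore follows the chain, falling as it shortens and rising as it grows, with the smaller change in chain giving the smaller step and none of the three going against this. Nothing available here accounts for the size of either step.

As far as these compounds go, whether the same trend holds for a branched chain such as isobutyl, or for a ring such as cyclohexyl at this position, remains open. So does the effect of a hydroxyl or a carboxylic acid at the end of the chain.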